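Swapping an azido group for phenylsulfanyl on a shared core

This account rests on a few compounds, and the source may have more. Where it says the series, first, only, none or still open, it means among the compounds named here.

Measured compounds:
- compound 1, `Nc1nc(O)c2c(n1)n(C1OC(CO)[C@@H](O)[C@H]1O)c(=O)n2Cc1ccc(Cl)c(Cl)c1`: 55%
- compound 2, `[N-]=[N+]=NCC(O)Cn1c(=O)n(C2OC(CO)[C@@H](O)[C@H]2O)c2nc(N)nc(O)c21`: 91%
- compound 3, `C=CCn1c(=O)n(CCC(CCOCc2ccccc2)CCOCc2ccccc2)c2nc(N)nc(O)c21`: 68%

In a functional assay on the whole organism (B cells) with Mus musculus as the target (a lower number here means a smaller maximal response, a higher number a larger maximal response), compound 2 reaches the highest of the three numbers. Its nearest neighbour is compound 3 with 68%, and the furthest is compound 1 with 55%; both gaps lie beyond the scatter.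

The new compound 4, `Nc1nc(O)c2c(n1)n(C1OC(CO)[C@@H](O)[C@H]1O)c(=O)n2CC(O)CSc1ccccc1`, is compound 2 with one change: phenylsulfanyl in place of azido on a saturated chain carbon, two bonds along the chain from an oxygen on a saturated carbon

Among the compounds with values here, one measured step bears on this. The step of a number 36 percentage points higher from compound 1 to compound 2 (beyond the scatter) replaced a group with an aromatic ring on the chain carbon bound to an aromatic nitrogen by the 2-azido-1-hydroxyethyl chain, and the response rose strongly. Compound 4 keeps the hydroxy chain but brings an aromatic ring back in, now as phenylsulfanyl. Within the data shown here, the data hold no step in which this exact group enters, so the step can only be judged from the direction of that one comparison. Compound 4 is therefore expected to give a smaller response than compound 2, with a number 21 percentage points lower from compound 2 to compound 4 (beyond the scatter) as the estimated step, and the value is expected to fall between compound 1 and compound 2 rather than below compound 1.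

For compound 4 the estimate in this assay is 70%, in the range 50% to 90%.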

Compound 4, largest response reached (reported as maximal response), in percent of the reference or control that the assay uses: 12%
Compound 4: middle estimate off by 58 percentage points, on the high side; the measured number lies below the stated range.
By their numbers in this assay, from the lowest: compound 4; then compound 1; then compound 3; then compound 2.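

In this assay, the group at the end of the hydroxy chain proves decisive: phenylsulfanyl in place of azido on a saturated chain carbon, two bonds along the chain from an oxygen on a saturated carbon, gives a number 79 percentage points lower from compound 2 to compound 4 (beyond the scatter) in a single change. The hydroxy chain alone therefore does not secure a large response, since replacing the 3,4-dichlorophenyl gave a number 36 percentage points higher from compound 1 to compound 2 (beyond the scatter) with the 2-azido-1-hydroxyethyl chain but a number 43 percentage points lower from compound 1 to compound 4 (beyond the scatter) with the 1-hydroxy-2-(phenylsulfanyl)ethyl chain, so the outcome reverses with the group at the chain end. No measurement shown here accounts for this drop.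

This one swap changes the sulfur, the aromatic ring and the number of heavy atoms together, so the compounds shown cannot separate the contribution of each. On these data alone, it also remains open whether a phenoxy group, with oxygen in place of sulfur, or a small amine at the same chain carbon would give a response closer to compound 2 or to compound 4.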